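A few compounds are considered here, and "the series" means these few. Any claim that something is new, unique, unknown or untested is made for them only; others in the source may bear on it.

Measured compounds in a functional assay (Homo sapiens) for inhibition; a higher number here means a weaker inhibitor, a lower number a stronger inhibitor: compound 1 `C/C(=C\COc1ccccc1)CC/C=C(\C)C1CC(=O)C(C)(C)O1` gives 27.6 ug/mL; compound 2 `C/C(=C\COc1c(Cl)cccc1Cl)CC/C=C(\C)C1=CC(=O)C(C)(C)O1` gives 27.4 ug/mL; compound 3 `COc1cccc(OC/C=C(\C)CC/C=C(\C)C2=CC(=O)C(C)(C)O2)c1` gives 35.9 ug/mL.

Compound 3 holds the highest of the three numbers in this assay, yet compound 1 and compound 2 both lie within the scatter of it, so no order among the three can be read. Compound 4 `C/C(=C\COc1ccccc1)CC/C=C(\C)C1=CC(=O)C(C)(C)O1` differs from compound 3 by hydrogen in place of methoxy on an aromatic carbon. Within the data shown here, one measured step bears on this change, the exchange of the aryl group, a 1.3-fold higher number from compound 2 to compound 3 (0.12 log units; within the scatter), which left the number essentially unchanged. Compound 1 carries the same phenyl group as compound 4, though on a different core, and its value sits close to that of compound 3. Among the measured compounds shown here, no measured step isolates the methoxy group itself. Compound 4 is therefore expected to show a 1.2-fold lower number from compound 3 to compound 4 (0.09 log units; within the scatter), nothing beyond the scatter. Compound 4 is estimated at 29 ug/mL, within 15 ug/mL to 56 ug/mL.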

Compound 4, half-maximal inhibitory concentration: 35.2 ug/mL
For compound 4 the middle estimate is 1.2-fold (0.08 log units) below the measured one, and the stated range covers the measured number.
By their numbers in this assay, from the lowest: compounds 2, 1, 4 and 3 (each within the scatter of the next).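

With hydrogen in place of methoxy on the aromatic carbon, the number in this assay holds level (a 1.0-fold lower number from compound 3 to compound 4 (0.01 log units; within the scatter)), so this direct test finds no measurable effect of the methoxy group. Phenyl and 2,6-dichlorophenyl also stand level on the shared core (a 1.3-fold higher number from compound 2 to compound 4 (0.11 log units; within the scatter)). With phenyl held constant, the exchange of the five-membered ring group likewise stays within the scatter (a 1.3-fold higher number from compound 1 to compound 4 (0.11 log units; within the scatter)). No measured evidence bears on this flatness. On these data alone, whether an amine or a carboxylic acid on the aromatic ring would move the number beyond the scatter remains open.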